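Fluoro to chloro: a swap with no direct precedent

The source may hold more compounds than are shown below. What is called first, only, known or untested is meant among the compounds shown, and "the series" means these compounds.

Compound 1 `O=S1(=O)c2ccccc2CN1c1cc(F)cc(Oc2cccnc2)c1`: 11000 nM
Compound 2 `O=S1(=O)c2ccccc2CN1c1cc(F)cc(Oc2ccccn2)c1`: 13000 nM

Both numbers come from a physicochemical assay for solubility, in phosphate buffer; on this read-out lower numbers stand for lower solubility and higher numbers for higher solubility. Only these two compounds have been measured, and they cannot be told apart: the result is a 1.2-fold higher number from compound 1 to compound 2 (0.07 log units; within the scatter). Within the data shown here, compound 2 therefore stands level with its one measured neighbour.

The next compound, compound 3 `O=S1(=O)c2ccccc2CN1c1cc(Cl)cc(Oc2ccccn2)c1`, keeps everything in compound 2 except one small group, chloro in place of fluoro on an aromatic carbon. Among the measured compounds shown here, the only measured step, a 1.2-fold higher number from compound 1 to compound 2 (0.07 log units; within the scatter), changes how the pyridine ring is attached and leaves the fluoro group untouched. For the measured compounds named here, it therefore bears on this swap only indirectly, and no measured pair tests fluoro against chloro. A modest move to a lower number in this assay is nevertheless expected, held with wide uncertainty. The expected change is a 2.2-fold lower number from compound 2 to compound 3 (0.34 log units; beyond the scatter). For compound 3 the estimated value is 6000 nM, with an expected range from 2500 nM to 14000 nM.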

Compound 3, solubility: 100 nM
Estimate against measurement, compound 3: 60-fold (1.78 log units) above, and the stated range ends above it.
By their numbers in this assay, from the lowest: compound 3; then compounds 1 and 2 (each within the scatter of the next).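

On the aromatic carbon meta to the (pyridin-2-yl)oxy group, the identity of the halogen counts for far more in this assay than the way the pyridine ring is attached. Chloro in place of fluoro gives a 130-fold lower number from compound 2 to compound 3 (2.11 log units; beyond the scatter), whereas the earlier change of ring attachment, a 1.2-fold higher number from compound 1 to compound 2 (0.07 log units; within the scatter), gave no readable difference. The two groups match in heavy-atom count, hydrogen-bond donors, hydrogen-bond acceptors and net charge, so those simple counts give no warning of a step this large, and nothing available here accounts for it.

The compounds shown leave open whether the same swap would move the number as far with the pyridin-3-yl ring of compound 1, since this single pair tests chloro against fluoro with the pyridin-2-yl ring only. They also cannot say whether the low number is particular to chloro or would appear with other groups on the same carbon, such as bromo, methyl, methoxy or an amine, each of which would help to show how sensitive this position is.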